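The source may report more compounds than this note shows. Statements on the series, on what has been measured and on what is new or still open speak of the compounds shown alone.

Measured in a functional assay on HCT-116 cells (Homo sapiens) for cytotoxicity, read by MTT assay, with a stated time of 72 h; a lower number here means a stronger inhibitor, a higher number a weaker inhibitor:
- compound 1 `O=C1c2c[n+]([O-])c3ccccc3c2C(=O)c2c1c1ccccc1n2Cc1cn([C@@H]2C[C@H](O)[C@@H](CO)O2)nn1`: 50 nM
- compound 2 `O=C1c2c[n+]([O-])c3ccccc3c2C(=O)c2c1c1ccccc1n2CCCCN1CCNCC1`: 700 nM

Of these two, compound 2 has the higher number at 700 nM, a gap to compound 1 that lies beyond the scatter. Compound 3 `CN(C)CCCCn1c2c(c3ccccc31)C(=O)c1c[n+]([O-])c3ccccc3c1C2=O` carries dimethylamino in place of piperazin-1-yl on a saturated chain carbon, four bonds along the chain from an aromatic nitrogen. Among the measured compounds shown here, no measured pair isolates this change, so no step beyond the scatter is expected in this assay. The expected move is a 1.4-fold lower number from compound 2 to compound 3 (0.15 log units; within the scatter). For compound 3 the estimate is 500 nM, with an expected range of 150 nM to 1800 nM.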

Compound 3, half-maximal inhibitory concentration: 450 nM
For compound 3 the middle estimate is 1.1-fold (0.05 log units) above the measured one; measured number inside the range.
By their numbers in this assay, from the lowest: compound 1; then compounds 3 and 2 (each within the scatter of the next).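

In this assay, a 1.6-fold lower number from compound 2 to compound 3 (0.19 log units; within the scatter), so dimethylamino and piperazin-1-yl cannot be told apart on a saturated chain carbon, four bonds along the chain from an aromatic nitrogen. On this chain, a value in this range therefore does not depend on the six-membered ring or the hydrogen-bond donor of piperazin-1-yl. Nothing measured here bears on why the two groups read alike.

Morpholin-4-yl, a primary amine or a carboxylic acid at this place remain open, as does a shorter or longer chain carrying dimethylamino. Compound 1 differs from compound 3 in more than one place, so what separates their values stays unresolved.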